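The source may hold more compounds than are shown below. What is called first, only, known or untested is meant among the compounds shown, and "the series" means these compounds.

Working notes on the sulfone series.

The series shares one core carrying a sulfonyl-linked aryl and a second aryl; compound 1 is `O=S(=O)(c1ccc(F)c(Cl)c1)c1cnc2cc(F)ccc2c1-c1ccc(Cl)cc1`, compound 2 is `O=S(=O)(c1cc(F)cc(F)c1)c1cnc2cc(F)ccc2c1-c1cccc(F)c1`, compound 3 is `O=S(=O)(c1ccc(F)c(Cl)c1)c1cnc2cc(F)ccc2c1-c1ccc(F)cc1`. Among the measured compounds shown here, in an assay (strain Sprague-Dawley) for displacement of a labelled ligand from metabotropic glutamate receptor 5 (Rattus norvegicus), with a stated time of 60 min (a higher number here means a weaker inhibitor, a lower number a stronger inhibitor), compound 1 gives 8.3 nM, the second highest of the three numbers so far. Compound 3 gives 5.2 nM, and the step of a 1.6-fold lower number from compound 1 to compound 3 (0.20 log units; within the scatter) is within the scatter. Compound 2 gives 32.6 nM; it differs from compound 1 in two places, on both aryl groups, so its value cannot be assigned to either change alone, only noted as the weakest number among the three.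

The unmeasured compound 4 is `O=S(=O)(c1cc(Cl)cc(Cl)c1)c1cnc2cc(F)ccc2c1-c1ccc(Cl)cc1`. It differs from compound 1 by 3,5-dichlorophenyl in place of 3-chloro-4-fluorophenyl on a sulfonyl sulfur. For the measured compounds named here, no measured step in this set changes the group on the sulfonyl sulfur alone; the one measured step, on the other aryl, was within the scatter. Compound 2, which carries a different sulfonyl aryl together with a different second aryl, gives the higher number noted above, so some weakening is possible but unproven. The expectation for this assay is therefore a step of a 1.4-fold higher number from compound 1 to compound 4 (0.16 log units; within the scatter), with a wide margin in both directions. For compound 4 the estimated inhibition constant is 12 nM, with a range from 4 nM to 40 nM.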

Compound 4, inhibition constant: 30.3 nM
Compound 4: the middle estimate sits 2.5-fold (0.40 log units) below what was measured, within the range that was stated.
By their numbers in this assay, from the lowest: compounds 3 and 1 (each within the scatter of the next); then compounds 4 and 2 (each within the scatter of the next).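

Among the compounds shown here, compound 1 and compound 4 give the first step read on the group on a sulfonyl sulfur alone: in this assay, 3,5-dichlorophenyl in place of 3-chloro-4-fluorophenyl gives a 3.7-fold higher number from compound 1 to compound 4 (0.56 log units; beyond the scatter) and so, unlike the one earlier step, on the other aryl, this change lies beyond the scatter. The number therefore responds to the sulfonyl aryl even though the two groups match in heavy atoms, in having one six-membered aromatic ring of carbon only, in hydrogen-bond donors and acceptors, and in having no net charge, so none of these counts separates them. Nothing measured in this set accounts for the step, and its origin remains unassigned.

With a single change read at this position, the compounds shown cannot separate the loss of fluorine from the gain of the second chlorine, nor show whether the step would carry over to a different second aryl such as the 4-fluorophenyl of compound 3. As far as these compounds go, how a methoxy, a nitrile or an amine on the sulfonyl aryl would compare with these halogen patterns also remains open.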